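This account rests on a few compounds, and the source may have more. Where it says the series, first, only, none or still open, it means among the compounds named here.

Compound 1 `COc1ccc(C(=O)Nc2cc(-c3ccccn3)n[nH]2)cc1`: > 40300 nM
Compound 2 `COc1ccc(C(=O)Nc2[nH]nc(-c3ccccn3)c2C2CC2)cc1`: > 64000 nM
Compound 3 `O=C(NCc1ccccc1)Nc1[nH]nc(-c2ccccn2)c1C1CC1`: > 45000 nM

In an ADME assay on cells (Peritoneal macrophage cell, Mus musculus) for cytotoxicity, read by fluorescence and resazurin assay, with a stated time of 3 days (on this read-out higher numbers stand for lower toxicity in this test and lower numbers for higher toxicity in this test), compound 1 gives > 40300 nM, which is a limit and not a number. Compound 2 and compound 3 likewise stand only at limits, so no ranking can be read.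

Compound 4 `O=C(Nc1cc(-c2ccccn2)n[nH]1)c1ccc(Cl)cc1` has chloro in place of methoxy on an aromatic carbon. Two measured changes bear on it only loosely: a step that the two limits leave unreadable from compound 1 to compound 2, and a step that the two limits leave unreadable from compound 2 to compound 3. Neither size can be read, and neither is this exchange. No step beyond the scatter is therefore expected in this assay, in either direction. The expected outcome is a number no higher from compound 1 to compound 4 (the limit leaves the size open). For compound 4 the estimate is 40000 nM, with an expected range of 15000 nM to 80000 nM.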

Compound 4, half-maximal cytotoxic concentration: > 64000 nM
Compound 4: a limit, no number (the forecaster's own chance of this, stated with the estimate: 65%); middle value at least 1.6-fold (0.20 log units) from the limit.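

In this assay compound 1 and compound 4 both stand only at limits, so chloro in place of methoxy gives no readable step. The compounds shown leave open at what concentration any of them becomes toxic to these cells.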